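Swapping the aryl group in a thromboxane synthase inhibitor

The source may hold more compounds than are shown below. What is called first, only, known or untested is meant among the compounds shown, and "the series" means these compounds.

Compound 2 `CSc1ccccc1OC(C)(C)C1OCC(C/C=C\CCC(=O)O)C(c2cccnc2)O1` is a close relative of compound 1 `CC(C)(Oc1ccccc1)C1OCC(C/C=C\CCC(=O)O)C(c2cccnc2)O1`. In an assay for inhibition of Thromboxane-A synthase (Homo sapiens), using microsomes (a lower number here means a stronger inhibitor, a higher number a weaker inhibitor), compound 1 gives 52 nM, and compound 2 gives 36 nM. Going by the values given here, the single step measured so far, a 1.4-fold lower number from compound 1 to compound 2 (0.16 log units; within the scatter), shifts the number only within the scatter, so compound 2 holds the lower of the two numbers without being separable from compound 1 by this assay. Compound 3 `COc1ccc(OC(C)(C)C2OCC(C/C=C\CCC(=O)O)C(c3cccnc3)O2)c([N+](=O)[O-])c1` has not yet been measured. It differs from compound 2 in one place: 4-methoxy-2-nitrophenyl in place of 2-(methylsulfanyl)phenyl on an oxygen on a saturated carbon. Among the compounds with values here, the only measured step that bears on this change is a 1.4-fold lower number from compound 1 to compound 2 (0.16 log units; within the scatter), which also altered the same aryl group and moved the number less than the scatter. That is thin ground, and the change leading to compound 3 is larger than that earlier one, so the uncertainty is wide. With nothing pointing to a shift in either direction, the expectation for compound 3 in this assay is a step of about a 1.3-fold higher number from compound 2 to compound 3 (0.10 log units; within the scatter), that is, no change beyond the scatter. The estimate for compound 3 is 45 nM, expected to fall between 15 nM and 150 nM.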

Compound 3, half-maximal inhibitory concentration: 37 nM
Compound 3: the middle estimate sits 1.2-fold (0.09 log units) above what was measured; the measured number falls inside the stated range.
By their numbers in this assay, from the lowest: compounds 2, 3 and 1 (each within the scatter of the next).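

In this assay, replacing the aryl group on an oxygen on a saturated carbon with 4-methoxy-2-nitrophenyl, which has 11 heavy atoms and 3 hydrogen-bond acceptors, gives a 1.0-fold higher number from compound 2 to compound 3 (0.01 log units; within the scatter) and a 1.4-fold lower number from compound 1 to compound 3 (0.15 log units; within the scatter) as the two new steps. The earlier step covered only the addition of methylsulfanyl, whereas these steps show that phenyl, 2-(methylsulfanyl)phenyl and 4-methoxy-2-nitrophenyl cannot be separated by this measurement, even though the last of these brings in a nitro group and a methoxy group at once. No supporting information is available to explain this lack of separation.

The compounds shown leave open whether any change at this place can move the number beyond the scatter, since all three carry an aryl group with no net charge. An aminomethyl group on the aryl ring, or a cyclohexyl group in place of the ring, would test this place with a group unlike any of the three.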